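This account rests on a few compounds, and the source may have more. Where it says the series, first, only, none or still open, it means among the compounds named here.

Measured so far in an ADME assay on HEp-2 cells (Homo sapiens) for cytotoxicity, read by CCK-8 assay, with a stated time of 5 days; a higher number here means that more compound is tolerated, a lower number that less compound is tolerated:

compound 1, `Cc1ccc2nc(N3CCCc4ccccc4C3)cc(NCCN)c2c1`: compound 1 gives 9400 nM
compound 2, `CNCCNc1cc(N2CCCc3ccc(F)cc3C2)nc2ccc(C)cc12`: compound 2 gives 29000 nM
compound 3, `Cc1ccc2nc(N3CCCc4ccc(F)cc4C3)cc(NC(C)(C)CN)c2c1`: compound 3 gives 25000 nM

Compound 3 stands second highest of the three numbers in this assay. Its nearest neighbour is compound 2, which differs from it only in the side chain on the ring nitrogen; that step, a 1.2-fold lower number from compound 2 to compound 3 (0.06 log units; within the scatter), lies within the scatter, so the two tolerated concentrations cannot be told apart. Among the measured compounds shown here, compound 1 is the furthest away, with a lower number than compound 3 that falls beyond the scatter; compound 1 and compound 3 differ in two places, so no single step connects them.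

Compound 4, `CC(=O)NCCNc1cc(N2CCCc3ccc(F)cc3C2)nc2ccc(C)cc12`, is the next compound. It differs from compound 3 in one place: 2-acetamidoethyl in place of 1-(aminomethyl)-1-methylethyl on a nitrogen on an aromatic ring. For the measured compounds named here, the only measured step that bears on this change is the one from compound 2 to compound 3, which also swapped the side chain on the same nitrogen and moved the number by a within-scatter amount. Going by the values given here, with that as the sole guide, the expected step of no change at the digits printed from compound 3 to compound 4 (within the scatter) is one of no clear direction and no size beyond the scatter. Compound 4 is therefore estimated to give about 25000 nM in this assay, in a range from 9000 nM to 65000 nM.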

Compound 4, half-maximal cytotoxic concentration: 66000 nM
The estimate for compound 4 lay 2.6-fold (0.42 log units) below the measured number; measured number outside the range, above it.
By their numbers in this assay, from the lowest: compound 1; then compounds 3 and 2 (each within the scatter of the next); then compound 4.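

In this assay, the side chain on this nitrogen now shows a change beyond the scatter: 2-acetamidoethyl in place of 1-(aminomethyl)-1-methylethyl gives a 2.6-fold higher number from compound 3 to compound 4 (0.42 log units; beyond the scatter), whereas the earlier swap on the same nitrogen gave only a 1.2-fold lower number from compound 2 to compound 3 (0.06 log units; within the scatter). The narrower comparison changes just the end of the chain, with acetyl in place of methyl on an amine nitrogen, and it gives a 2.3-fold higher number from compound 2 to compound 4 (0.36 log units; beyond the scatter), so this one substitution gives a modest step of similar size and in the same direction as the change from compound 3. Nothing measured here says why the number rises, and these cytotoxicity values alone cannot supply an explanation.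

From the compounds shown here alone, it remains open whether the higher number is particular to acetyl or would also appear with another group on that amine nitrogen, such as a propanoyl or a methanesulfonyl group, or with a carboxylic acid at the end of the chain. It is also unknown whether acetyl on the terminal amine of compound 1 would give a similar step on the core of that compound.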